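Swapping the benzylic aryl ring in a bis(trifluoromethyl)benzenesulfonamide series

The source may hold more compounds than are shown below. What is called first, only, known or untested is meant among the compounds shown, and "the series" means these compounds.

In a toxicity assay on MCF-10A cells (Homo sapiens) for inhibition, read by MTT assay, with a stated time of 72 h (a lower number here means a stronger inhibitor of growth, a higher number a weaker inhibitor of growth), compound 2 `O=S(=O)(NCCCNCc1ccc(Cl)c(C(F)(F)F)c1)c1cc(C(F)(F)F)cc(C(F)(F)F)c1` gives 7900 nM, the second highest of the three numbers measured. Compound 3 `CC(C)(C)c1ccc(CNCCNS(=O)(=O)c2cc(C(F)(F)F)cc(C(F)(F)F)c2)cc1` gives 14000 nM, which lies within the scatter of compound 2, while compound 1 `O=S(=O)(NCCNCc1ccc(-c2ccccc2)cc1)c1cc(C(F)(F)F)cc(C(F)(F)F)c1` gives 3300 nM, a number beyond the scatter below it.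

Compound 4 `COc1cccc(CNCCCNS(=O)(=O)c2cc(C(F)(F)F)cc(C(F)(F)F)c2)c1` has not yet been measured in this assay. It differs from compound 2 in one place: 3-methoxyphenyl in place of 4-chloro-3-(trifluoromethyl)phenyl on a saturated chain carbon bound to an amine nitrogen.

For the measured compounds named here, only one measured step concerns the aromatic ring that sits on the saturated chain carbon bound to an amine nitrogen, namely a 4.2-fold higher number from compound 1 to compound 3 (0.63 log units; beyond the scatter). That step, however, exchanges groups other than those exchanged here, and compounds 1 and 3 share a core that is not the core of compound 2, so it is at best a loose guide. It suggests that such ring changes can move the number by a modest amount, but gives no direction for a 3-methoxyphenyl ring.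

Compound 4 is therefore expected to land near compound 2, with an estimated step of a 1.0-fold higher number from compound 2 to compound 4 (0.01 log units; within the scatter) that may not exceed the scatter. The estimate for compound 4 in this assay is 8000 nM, within a range from 3000 nM to 20000 nM.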

Compound 4, concentration for 50% growth inhibition: 6600 nM
The estimate for compound 4 lay 1.2-fold (0.08 log units) above the measured number; measured number inside the range.
By their numbers in this assay, from the lowest: compounds 1, 4, 2 and 3 (each within the scatter of the next, the first and the last beyond it).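

For the compounds shown here, the step of a 1.2-fold lower number from compound 2 to compound 4 (0.08 log units; within the scatter) is the first reading of the aromatic ring on a saturated chain carbon bound to an amine nitrogen within the core of compound 2, and in this assay it stays within the scatter. The exchange is not a small one: 4-chloro-3-(trifluoromethyl)phenyl, with 11 heavy atoms including chlorine and fluorine, leaves, and 3-methoxyphenyl, with 8 heavy atoms including oxygen and 1 hydrogen-bond acceptor, enters, so in this core neither the chlorine nor the trifluoromethyl group is needed for a number of this size. Nothing measured here explains why the two numbers stay so close.

Because the chlorine, the trifluoromethyl group and the methoxy group change together, the step cannot show what each contributes alone, and the two rings may also hide opposing contributions. Going by these compounds, it remains open whether this tolerance extends to a ring carrying a carboxylic acid or an amine, and whether 3-methoxyphenyl would behave in the same way on the core of compound 1.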